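Swapping a Fluorophenyl for an Ethylphenyl on the Sulfonamide

The compounds below may be only part of what the source reports. "The series", "measured", "known", "first", "only" and "open" are said of these compounds alone.

Measured so far:
compound 1, `O=S(=O)(Nc1ccc(-c2nc3ccccc3o2)cc1)c1cccc(F)c1`, > 100000 nM
compound 2, `O=[N+]([O-])c1cc(S(=O)(=O)Nc2ccc(-c3nc4ccccc4o3)cc2)ccc1Cl`, 85000 nM

Both measured compounds share the same core and differ only in the aryl group on the sulfonyl sulfur. In an ADME assay on HEK293 cells (Homo sapiens) for cytotoxicity, read by resazurin assay, with a stated time of 48 h (on this read-out higher numbers stand for lower toxicity in this test and lower numbers for higher toxicity in this test), compound 1 reaches only a limit, > 100000 nM, so no number is known for it; it sits at the limit of > 100000 nM in this assay, at which 1 of the 2 values shown sits. Compound 2 gives 85000 nM in this assay.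

Compound 3, `CCc1ccc(S(=O)(=O)Nc2ccc(-c3nc4ccccc4o3)cc2)cc1`, has not yet been measured in this assay. It differs from compound 1 by 4-ethylphenyl in place of 3-fluorophenyl on a sulfonyl sulfur. Nothing measured here shows how this aryl group affects toxicity, and both known values lie near the upper end of the assay. The step of a number no higher from compound 1 to compound 3 (the limit leaves the size open) is therefore expected to be none beyond the scatter. For compound 3 an estimate of 100000 nM is expected, within a range from 50000 nM to 200000 nM, with a fair chance that only a limit is reported.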

Compound 3, half-maximal cytotoxic concentration: 82000 nM
Estimate against measurement, compound 3: 1.2-fold (0.09 log units) above, and the stated range covers the measured number.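

Putting 4-ethylphenyl in place of 3-fluorophenyl on a sulfonyl sulfur gives an at least 1.2-fold lower number from compound 1 to compound 3 (0.08 log units; that floor lies within the scatter). Going by these compounds, the true size of this step stays open because one end of it is not a number: the limit of > 100000 nM in this assay, at which 1 of the 3 values shown sits. Compound 3, with 4-ethylphenyl, gives 82000 nM, and compound 2, with its different aryl group, gives 85000 nM, so these two measured values lie close together and both are high on this read-out.

Whether an amine or a carboxylic acid on this aryl ring would move the number in this assay any more clearly than the groups shown remains open. So does the outcome for a longer chain in place of the ethyl group, or for a sulfonyl sulfur carrying no aromatic ring at all.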